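Allyl to benzyl in a weak inhibitor

The source may hold more compounds than are shown below. What is called first, only, known or untested is meant among the compounds shown, and "the series" means these compounds.

In a functional assay on MDA-MB-231 cells (Homo sapiens) for inhibition, read by sulforhodamine B assay, with a stated time of 48 h (a lower number here means a stronger inhibitor, a higher number a weaker inhibitor), compound 1 (`C=CCC(O)(c1ccc(OC)c(OC)c1OC)c1cccc2ccccc12`) gives > 20000 nM, which is a limit of the assay and not a number. Going by the values given here, the only actual number so far belongs to compound 2 (`COc1ccc(/C(=C\c2ccc(F)cc2)c2cccc3ccccc23)c(OC)c1OC`), at 16200 nM. Compound 3 (`COc1ccc(C(O)(Cc2ccccc2)c2cccc3ccccc23)c(OC)c1OC`) has phenyl in place of vinyl on a saturated chain carbon, allyl to benzyl when read one bond further out: phenyl in place of vinyl on a saturated chain carbon, two bonds along the chain from two aromatic carbons and an oxygen on a saturated carbon. Among the compounds with values here, no measured step shows what this swap does, so only a small move toward stronger inhibition is expected in this assay. That expectation is an at least 1.4-fold lower number from compound 1 to compound 3 (0.15 log units; that floor lies within the scatter). For compound 3 the estimated value is 14000 nM, with an expected range from 5000 nM to 40000 nM.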

Compound 3, half-maximal inhibitory concentration: 4780 nM
Beside the measured number, compound 3's estimate is 2.9-fold (0.47 log units) above it, and the stated range ends above it.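

Going by these compounds alone, this is the first reading of a change at this position: in this assay, phenyl in place of vinyl on the saturated chain carbon gives an at least 4.1-fold lower number from compound 1 to compound 3 (0.62 log units; beyond the scatter). So this place on the chain responds to the group it carries, and the larger aromatic group goes with the stronger inhibitor of this pair. The true size of the step stays unknown, because compound 1 gives only a limit of the assay and not a number: the limit of > 20000 nM in this assay, at which 1 of the 3 values shown sits.

From the compounds shown here alone, whether the aromatic ring itself matters remains open, since a saturated group such as cyclohexyl could show that. An amine on the phenyl ring would show whether this place accepts further change.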